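Urea aryl cap: methyl to hydrogen

This account rests on a few compounds, and the source may have more. Where it says the series, first, only, none or still open, it means among the compounds named here.

The series keeps one shared core and varies only the aryl group on the urea. Compound 1 `Cc1ccc(NC(=O)Nc2cccc(CNc3nccnc3Cl)c2)cc1C` gives 8930 nM in a functional assay on T-24 cells (Homo sapiens) for antiproliferative activity, read by MTT assay, with a stated time of 48 h; a lower number here means a stronger inhibitor, a higher number a weaker inhibitor. Compound 2 `Cc1ccc(NC(=O)Nc2cccc(CNc3nccnc3Cl)c2)cc1` gives 9820 nM in this assay. Compound 3 `O=C(Nc1cccc(CNc2nccnc2Cl)c1)Nc1cccc2ccccc12` is recorded only as a limit of the assay, > 40000 nM in this assay, not as a number. Of the two numbers in hand, compound 2 carries the highest, with compound 1 nearest; the step of a 1.1-fold higher number from compound 1 to compound 2 (0.04 log units; within the scatter) sits within the scatter, so no order between the two is claimed.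

Compound 4 `O=C(Nc1ccccc1)Nc1cccc(CNc2nccnc2Cl)c1` differs from compound 2 by hydrogen in place of methyl on an aromatic carbon. Among the measured compounds shown here, the only measured step of this kind, a 1.1-fold higher number from compound 1 to compound 2 (0.04 log units; within the scatter), stayed within the scatter. The move to compound 4 is therefore expected to give no change beyond the scatter in this assay, an expected step of a 1.2-fold higher number from compound 2 to compound 4 (0.09 log units; within the scatter). Compound 4 is estimated at 12000 nM in this assay, with an expected range from 5000 nM to 30000 nM.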

Compound 4, half-maximal inhibitory concentration: 19800 nM
The estimate for compound 4 lay 1.7-fold (0.22 log units) below the measured number; the range from low to high includes it.
By their numbers in this assay, from the lowest: compounds 1, 2 and 4 (each within the scatter of the next, the first and the last beyond it). At a limit, above all of these: compound 3.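

Hydrogen in place of methyl at the position para to a large group now has a second reading in this assay: a 2.0-fold higher number from compound 2 to compound 4 (0.30 log units; within the scatter). Neither methyl step leaves the scatter when read alone, so no single methyl can be credited with a separate contribution on this evidence. Taken together as phenyl in place of 3,4-dimethylphenyl on the amide-type nitrogen, the change does clear the scatter, though only modestly: a 2.2-fold higher number from compound 1 to compound 4 (0.35 log units; beyond the scatter).

As far as these compounds go, compound 3 is a limit of the assay and not a number, and its distance from the other compounds stays open: the limit of > 40000 nM in this assay, at which 1 of the 4 values shown sits. Also open, from the compounds shown here alone, is how an amine, a carboxylic acid or a methoxy group in place of the methyl would read in this assay.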